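The source may hold more compounds than are shown below. What is called first, only, known or untested is meant among the compounds shown, and "the series" means these compounds.

Compound 1 `Cc1ccc(C)c(-c2csc(NC(=O)c3ccc(S(=O)(=O)N4CCCCC4)cc3)n2)c1` gives 2300 nM in an assay on tissue (THP1-Blue NF-kappaB cells) for activation of nuclear factor NF-kappa-B complex (Homo sapiens), read by colorimetric assay, with a stated time of 20 h, in the presence of a further agent that is not named here; on this read-out higher numbers stand for an effect only at larger amounts of compound and lower numbers for an effect already at smaller amounts. Compound 2 `Cc1ccc(Br)c(-c2csc(NC(=O)c3ccc(S(=O)(=O)N4CCCCC4)cc3)n2)c1` gives 4500 nM in this assay.

Compound 1 and compound 2 lie within the scatter of each other, as a 2.0-fold higher number from compound 1 to compound 2 (0.29 log units; within the scatter) shows, so neither stands apart on the numbers shown. Compound 3 `CCCC#Cc1sc(NC(=O)c2ccc(S(=O)(=O)N3CCCCC3)cc2)nc1-c1cc(C)ccc1C` differs from compound 1 by pent-1-yn-1-yl in place of hydrogen on an aromatic carbon. Among the measured compounds shown here, the single measured step concerns a different place and a different kind of change, so no measured step bears on this one. Without guidance, no shift beyond the scatter is expected, which means a 1.1-fold higher number from compound 1 to compound 3 (0.04 log units; within the scatter). Compound 3 is therefore estimated at 2500 nM, with a range from 600 nM to 10000 nM.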

Compound 3, half-maximal effective concentration: 1700 nM
Beside the measured number, compound 3's estimate is 1.5-fold (0.17 log units) above it; low and high end bracket the measured number.
By their numbers in this assay, from the lowest: compounds 3, 1 and 2 (each within the scatter of the next, the first and the last beyond it).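

The aromatic carbon next to the ring sulfur, which bears hydrogen in compound 1, takes pent-1-yn-1-yl in this assay with a 1.4-fold lower number from compound 1 to compound 3 (0.13 log units; within the scatter) and so stays within the scatter. Among the compounds shown here, the earlier pair spoke only to a change at another place on the shared core, so this is the only reading for this position. Nothing measured here accounts for this result. Going by these compounds, whether a longer chain, an amine or a carboxylic acid at this position would also stay within the scatter remains open. On these data alone, it is also open whether the same change would read alike on compound 2.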